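Naphthyloxy-ethylamine series: N-substituent steps toward compound 4

This account rests on a few compounds, and the source may have more. Where it says the series, first, only, none or still open, it means among the compounds named here.

Measured so far in a functional assay for agonist activity at 5-hydroxytryptamine receptor 1B (Homo sapiens); a higher number here means a weaker inhibitor, a lower number a stronger inhibitor:
compound 1 `NCCCOc1cccc2ccccc12` gives 290 nM
compound 2 `CNCCOc1cccc2ccccc12` gives 26 nM
compound 3 `CCNCCOc1cccc2ccccc12` gives 66 nM

Compound 3 sits second of the three numbers: a 2.5-fold higher number from compound 2 to compound 3 (0.40 log units; beyond the scatter), while a 4.4-fold lower number from compound 1 to compound 3 (0.64 log units; beyond the scatter). The largest step is an 11-fold lower number from compound 1 to compound 2 (1.05 log units; beyond the scatter).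

Compound 4 `OCCNCCOc1cccc2ccccc12` differs from compound 3 by hydroxy in place of hydrogen on a saturated chain carbon, two bonds along the chain from an amine nitrogen. For the measured compounds named here, the only step that bears on growing the substituent on the amine is the modest one from compound 2 to compound 3; no measured step adds a hydroxy to this chain, so its effect is unknown. Expected for compound 4 is therefore a small step, a 1.4-fold higher number from compound 3 to compound 4 (0.13 log units; within the scatter), not clearly beyond the scatter. The estimate for compound 4 is 90 nM, within 30 nM to 270 nM.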

Compound 4, inhibition constant: 107 nM
The estimate for compound 4 lay 1.2-fold (0.08 log units) below the measured number, and the stated range covers the measured number.
By their numbers in this assay, from the lowest: compound 2; then compounds 3 and 4 (each within the scatter of the next); then compound 1.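

In this assay, for the compounds shown here, hydroxy on the saturated chain carbon two bonds along the chain from the amine nitrogen is a change that can be read at this position for the first time, and it stays within the scatter: a 1.6-fold higher number from compound 3 to compound 4 (0.21 log units; within the scatter). The (2-hydroxyethyl)amino group still leaves a clear gap to methylamino, a 4.1-fold higher number from compound 2 to compound 4 (0.61 log units; beyond the scatter), and a clear gap to compound 1, a 2.7-fold lower number from compound 1 to compound 4 (0.43 log units; beyond the scatter). Nothing at hand accounts for these steps.

Open, going by these compounds, is whether methoxy in place of this hydroxy, or a longer chain such as 3-hydroxypropyl on the amine, would hold the number of compound 4.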